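Notes on a pyridinyl benzamide series: compound 3 to compound 4

A few compounds are considered here, and "the series" means these few. Any claim that something is new, unique, unknown or untested is made for them only; others in the source may bear on it.

Measured so far in an in vitro assay on HEK-tsA201 cells for antagonist activity at Neuronal acetylcholine receptor; alpha4/beta2 (Homo sapiens), read by fluorescence and calcium flux; on this read-out lower numbers stand for stronger inhibition and higher numbers for weaker inhibition:
compound 1 `C=C(C)COc1ccc(C(=O)Nc2cccc(C)n2)cc1`: 19600 nM
compound 2 `C=CCOc1ccc(C(=O)Nc2cccc(Cl)n2)cc1`: the assay reports only a limit, > 100000 nM
compound 3 `CCCCCNc1cccc(NC(=O)c2ccc(OCCC)cc2)n1`: the assay reports only a limit, > 100000 nM

Compound 3 stands at the limit of this assay, not at a number. Of the three values shown, two sit at such a limit (the limit of > 100000 nM in this assay, at which 2 of the 3 values shown sit), and only compound 1 carries a measured number, which is itself weak. Among the compounds with values here, no two measured compounds differ in a single place, so no measured step can be drawn from these figures, and nothing measured tells whether a change on the amide-bearing ring moves the read-out.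

Compound 4 `CCCOc1ccc(C(=O)Nc2cccc(N3CCCCC3)n2)cc1` is not yet measured. Compared with compound 3 the change is piperidin-1-yl in place of pentylamino on an aromatic carbon. The chain and the ring carry the same count of heavy atoms; the donor on the nitrogen is lost.

Expected in this assay: the step of a number no higher from compound 3 to compound 4 (the limit leaves the size open) is taken as none beyond the usual scatter, since compound 3 starts at the limit and compound 1 is also weak. Compound 4 is therefore expected near 100000 nM, within 30000 nM to 300000 nM, with a real chance that this assay again reports only a limit.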

Compound 4, half-maximal inhibitory concentration: > 100000 nM
Compound 4 ended at the assay's limit; the forecaster's own chance of this, stated with the estimate: 70%; the middle value lies on the limit itself.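

In this assay compound 4 gives > 100000 nM, which is a limit of the assay and not a number; compound 3 also stands at a limit, so no step can be read between the two. The compounds shown leave open whether piperidin-1-yl in place of pentylamino changes the read-out at all, with most values at one limit: the limit of > 100000 nM in this assay, at which 3 of the 4 values shown sit.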